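The compounds below may be only part of what the source reports. "The series", "measured", "known", "first", "only" and "open" are said of these compounds alone.

Compound 1 `Cc1nc(Cn2c(=O)[nH]c3c(N)nc(C(F)(F)F)cc32)co1`: < 8 mL.min-1.g-1
Compound 2 `Nc1nc(C(F)(F)F)cc2c1[nH]c(=O)n2Cc1ccc(C(F)(F)F)nc1`: < 7 mL.min-1.g-1

In an in vitro ADME assay on microsomes from liver (Homo sapiens) for metabolic stability (a higher number here means faster removal of the compound, a lower number slower removal), compound 2 stands at < 7 mL.min-1.g-1, which is a limit and not a number. Compound 1 likewise gives only a limit. Compound 3 `COc1ccc(Cn2c(=O)[nH]c3c(N)nc(C(F)(F)F)cc32)cn1` has methoxy in place of trifluoromethyl on an aromatic carbon, next to the ring nitrogen (methoxy in place of trifluoromethyl on an aromatic carbon). For the measured compounds named here, the series holds no measured step to size this change, so the expectation is loose. A modest rise in clearance is expected, with an estimated step of an at least 1.4-fold higher number from compound 2 to compound 3 (0.15 log units; that floor lies within the scatter). For compound 3 the expected value is 10 mL.min-1.g-1, with an estimated range of 5 mL.min-1.g-1 to 25 mL.min-1.g-1.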

Compound 3, intrinsic clearance in microsomes in the Homo sapiens assay: < 8 mL.min-1.g-1
Compound 3 gave a limit, no number (the forecaster's own chance of this, stated with the estimate: 40%); middle value at least 1.2-fold (0.09 log units) from the limit.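

In the Homo sapiens assay compound 1 gives < 8 mL.min-1.g-1 as a limit and not a number. In the Homo sapiens assay compound 2 gives < 7 mL.min-1.g-1 as a limit and not a number. In the Homo sapiens assay compound 3 gives < 8 mL.min-1.g-1 as a limit and not a number. For the compounds shown here, no step between these compounds can be read. The compounds shown leave open whether methoxy in place of trifluoromethyl changes intrinsic clearance at all, and by how much. In a physicochemical assay for lipophilicity, measured as octanol-water partition, at pH 7.4 (a lower number here means a more polar compound, a higher number a more lipophilic compound), compound 2 is recorded as "not determined" (no result reported) and has no reported result. In the physicochemical assay compound 3 gives 2.8 as its distribution coefficient.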